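Toward Compound 3: Swapping the Pyrimidine for a Pyridyl Ether

The source may report more compounds than this note shows. Statements on the series, on what has been measured and on what is new or still open speak of the compounds shown alone.

Compound 1, `O=C1C(=O)N(Cc2ccc(-c3cccnc3)cc2)c2ccc(OC(F)(F)F)cc21`: 51%
Compound 2, `O=C1C(=O)N(Cc2ccc(-c3cncnc3)cc2)c2ccc(OC(F)(F)F)cc21`: 53%

For the measured compounds named here, in a functional assay on CHO cells for positive allosteric modulation of muscarinic acetylcholine receptor M5 (Homo sapiens), read by FLIPR and calcium flux, with a stated time of 1 h (on this read-out lower numbers stand for smaller maximal responses and higher numbers for larger maximal responses), compound 2 holds the larger of the two numbers, yet the single measured step, a number 2 percentage points higher from compound 1 to compound 2 (within the scatter), means the two compounds cannot be told apart. Compound 3, `O=C1C(=O)N(Cc2ccc(Oc3ccccn3)cc2)c2ccc(OC(F)(F)F)cc21`, differs from compound 2 by (pyridin-2-yl)oxy in place of pyrimidin-5-yl on an aromatic carbon. Going by the values given here, no measured step involves a (pyridin-2-yl)oxy group, so the only guide is that the one known change left the maximal response essentially unmoved. Compound 3 is therefore expected to give a step of a number 3 percentage points lower from compound 2 to compound 3 (within the scatter), nothing beyond the scatter. The estimated value of compound 3 is 50%, ranging from 30% to 70%.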

Compound 3, largest response reached (Emax), in percent of the reference or control that the assay uses: 46%
Beside the measured number, compound 3's estimate is 4 percentage points above it; the measured number falls inside the stated range.
By their numbers in this assay, from the lowest: compounds 3, 1 and 2 (each within the scatter of the next).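

In this assay, putting an oxygen link between the ring and the rest of the molecule, as the (pyridin-2-yl)oxy group does, gives a number 7 percentage points lower from compound 2 to compound 3 (within the scatter) and a number 5 percentage points lower from compound 1 to compound 3 (within the scatter). At this place, para to a large group, the maximal response therefore stays within the scatter across a change larger than swapping one ring nitrogen pattern for another. Nothing available explains why the response holds. Still open, on these data alone, is whether an amine or a carboxylic acid at this place, with no aromatic ring, would move the response beyond the scatter.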